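Chromanone series: single stereocentre drawn versus undrawn

The source may hold more compounds than are shown below. What is called first, only, known or untested is meant among the compounds shown, and "the series" means these compounds.

Measured so far:
- compound 1, `COc1ccc(C2CC(=O)c3ccc(C)cc3O2)cc1`, 3350 nM
- compound 2, `COc1ccc2c(c1)OC(c1ccccc1)CC2=O`, 1470 nM
- compound 3, `Cc1ccc2c(c1)O[C@H](c1ccccc1)CC2=O`, 110 nM

All three numbers come from an in vitro assay on BTI-TN-5B1-4 cells for inhibition of Amine oxidase [flavin-containing] B (Homo sapiens); a higher number here means a weaker inhibitor, a lower number a stronger inhibitor. Compound 3 has the lowest number of the three. The nearest is compound 2, whose number is higher by a margin beyond the scatter; the furthest is compound 1, higher still and also beyond the scatter. Compound 3 is therefore the strongest inhibitor of the three on these numbers.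

Compound 4, `Cc1ccc2c(c1)OC(c1ccccc1)CC2=O`, is not yet measured in this assay. Compared with compound 3 the change is: the two compounds have the same atoms and bonds; at least one stereo element is drawn with a configuration in one of them and without one in the other: 1 of 1 stereo elements differ; a stereocentre at a saturated ring carbon is drawn S in compound 3 and without a configuration in compound 4. No atom leaves and none enters; only the drawn configuration at that stereocentre differs.

For the measured compounds named here, no step between two measured compounds of this kind exists in the data, so the size of this step cannot be read from a precedent. If compound 4 contains both configurations at that centre, and compound 3 carries the more active one, a move to a somewhat higher number in this assay is expected, at the edge of the scatter; the step from compound 3 to compound 4 is estimated at a 1.8-fold higher number from compound 3 to compound 4 (0.26 log units; within the scatter). For compound 4 the expected value in this assay is 200 nM, within a range from 100 nM to 450 nM.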

Compound 4, half-maximal inhibitory concentration: 3620 nM
Compound 4: middle estimate off by 18-fold (1.26 log units), on the low side; the whole stated range lies below it.
By their numbers in this assay, from the lowest: compound 3; then compound 2; then compounds 1 and 4 (each within the scatter of the next).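

In this assay, the drawn configuration at the stereocentre at a saturated ring carbon is the only difference behind a 33-fold higher number from compound 3 to compound 4 (1.52 log units; beyond the scatter), the largest step in this set, with atoms and bonds unchanged: the fact that one of compounds 3 and 4 is drawn with a defined configuration and the other without, at the place where they differ

The aromatic changes weigh less by comparison: methyl in place of methoxy on an aromatic carbon gives a 2.5-fold higher number from compound 2 to compound 4 (0.39 log units; beyond the scatter), and hydrogen in place of methoxy on an aromatic carbon gives a 1.1-fold higher number from compound 1 to compound 4 (0.03 log units; within the scatter). For the compounds shown here, the stereocentre therefore has the largest link to the numbers so far, though the composition of compound 4 at that centre is not known.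

Still open, on these data alone, is how a compound drawn with the opposite configuration would read, which would show whether the gap reflects configuration alone. Also open, as far as these compounds go, is whether an amine or a carboxylic acid on an aromatic carbon would be tolerated with the configuration of compound 3.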